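Changing the Aryl Group: Expected Effect on Cell Growth Inhibition

A few compounds are considered here, and "the series" means these few. Any claim that something is new, unique, unknown or untested is made for them only; others in the source may bear on it.

Compound 1 `COc1cc(C2=NN(C(C)=O)C(c3c(Cl)cccc3Cl)O2)cc(OC)c1OC`: -2.2%
Compound 2 `COc1cc(C2=NN(C(C)=O)C(c3ccccc3F)O2)cc(OC)c1OC`: 31.6%

In a functional assay on PC-3 cells (Homo sapiens) for antiproliferative activity, read by MTT assay, tested at 5 uM (on this read-out lower numbers stand for a weaker effect and higher numbers for a stronger effect at the one concentration tested), compound 1 gives -2.2%, while compound 2 gives 31.6%. Among the compounds with values here, compound 2 stands highest of the two numbers, and the only measured step, a number 33.8 percentage points higher from compound 1 to compound 2 (beyond the scatter), shows that exchanging the group on this saturated ring carbon can move this assay strongly. Compound 3 `COc1cc(C2=NN(C(C)=O)C(c3ccc(Cl)c([N+](=O)[O-])c3)O2)cc(OC)c1OC` differs from compound 2 at that same place: 4-chloro-3-nitrophenyl in place of 2-fluorophenyl on a saturated ring carbon. Within the data shown here, no measured step tests this particular group, so the direction is uncertain, and only the size of the earlier step suggests how far the number may move. Compound 3 is therefore estimated to give 20%, with an expected range from -5% to 45%. This estimate means an expected step of a number 11.6 percentage points lower from compound 2 to compound 3 (beyond the scatter).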

Compound 3, a percentage reported as inhibition, at one concentration (the size of the read-out at that concentration, not a potency): 61.4%
The estimate for compound 3 lay 41.4 percentage points below the measured number, outside the stated range (above it).
By their numbers in this assay, from the lowest: compound 1; then compound 2; then compound 3.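

In this assay, the saturated ring carbon tolerates more than the earlier pair suggested: 4-chloro-3-nitrophenyl in place of 2-fluorophenyl gives a number 29.8 percentage points higher from compound 2 to compound 3 (beyond the scatter). Compound 3 also stands far from the 2,6-dichlorophenyl compound, with a number 63.6 percentage points higher from compound 1 to compound 3 (beyond the scatter), so the choice of aryl group alone spans a wide range here. Nothing available explains why this group gives the highest number. The compounds shown leave open whether the chlorine or the nitro group matters more, as the two appear only together. From the compounds shown here alone, whether an amine or a carboxylic acid in place of the nitro group would keep this level also remains open.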